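The compounds below may be only part of what the source reports. "The series", "measured", "known", "first", "only" and "open" are said of these compounds alone.

Going by the values given here, in a functional assay on CNS cells (Homo sapiens) for antiproliferative activity (a lower number here means a stronger inhibitor of growth, a higher number a weaker inhibitor of growth), compound 1 `Cc1sc2nc(-c3ccncc3)c(/C=N/NC(=N)N)n2c1C` gives 38900 nM and is the weaker of the two compounds measured so far. Compound 2 `N=C(N)N/N=C/c1c(-c2ccccn2)nc2sc(Cl)cn12` gives 5620 nM as the lower of the two numbers, which makes it the stronger growth inhibitor of the pair, and the gap between them lies beyond the usual scatter. Among the compounds with values here, these two compounds differ in more than one place, so no measured pair shows a single change on its own.

Within the data shown here, compound 3 `N=C(N)N/N=C/c1c(-c2ccncc2)nc2sc(Cl)cn12` has the same atoms as compound 2 joined differently, with pyridin-4-yl in place of pyridin-2-yl on an aromatic carbon as the only change. With compound 1 at 38900 nM as the sole measured carrier of pyridin-4-yl, a small rise is expected rather than a fall, although this is thin evidence. The expected shift is a 1.4-fold higher number from compound 2 to compound 3 (0.15 log units; within the scatter) and it should stay within the usual scatter. The estimate for compound 3 is 8000 nM with 2200 nM to 30000 nM as its expected range.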

Compound 3, concentration for 50% growth inhibition: 7760 nM
Compound 3: the middle estimate sits 1.0-fold (0.01 log units) above what was measured; the measured number falls inside the stated range.
By their numbers in this assay, from the lowest: compounds 2 and 3 (each within the scatter of the next); then compound 1.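

In this assay, putting pyridin-4-yl in place of pyridin-2-yl on this aromatic carbon gives a 1.4-fold higher number from compound 2 to compound 3 (0.14 log units; within the scatter), so compound 2 and compound 3 cannot be told apart. Going by these compounds alone, this is the first pair in which a single change can be read on its own, and it shows that, on the core shared by these two compounds, these two pyridine attachments give growth inhibition that is indistinguishable in this measurement. Nothing available here bears on why the two compounds match.

Only these two pyridine attachments are shown at this position, so it remains open whether pyridin-3-yl, a plain phenyl ring or a ring-free group such as an amine would also match them, or would move the number beyond the usual scatter. Compound 1 also carries pyridin-4-yl but differs from compound 3 in more than one place on the core, so the gap between their numbers cannot yet be tied to any single change.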